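The compounds below may be only part of what the source reports. "The series", "measured", "known", "first", "only" and "open" are said of these compounds alone.

Measured compounds:
Compound 1, `CS(=O)(=O)N1CCN(CC(O)CN2CCC(CNC(=O)c3cccc4[nH]cnc34)CC2)CC1`: 10 nM
Compound 2, `COC(=O)N1CCN(CCN2CCC(CNC(=O)c3cccc4[nH]c(C(C)C)nc34)CC2)CC1`: 1.59 nM
Compound 3, `CC(C)(C)c1nc2c(C(=O)NCC3CCN(CC(O)CN4CCN(S(C)(=O)=O)CC4)CC3)cccc2[nH]1`: 3.16 nM

In a functional assay for agonist activity at 5-hydroxytryptamine receptor 4 (Homo sapiens), read by cAMP accumulation (a lower number here means that less compound is needed, a higher number that more compound is needed for the effect), compound 2 gives the lowest of the three numbers. Its nearest neighbour is compound 3, whose number is higher by an amount that stays within the scatter, so the two cannot be ranked against each other. Compound 1 lies furthest away, and there the gap is beyond the scatter. Going by the values given here, the one step that can be read off between measured compounds is a 3.2-fold lower number from compound 1 to compound 3 (0.50 log units; beyond the scatter), a tert-butyl in place of hydrogen on an aromatic carbon on the common core.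

Compound 4, `COC(=O)N(C)CC(O)CN1CCC(CNC(=O)c2cccc3[nH]c(C(C)C)nc23)CC1`, is the next compound to be tested. Compared with compound 2 it carries 1-hydroxy-2-((methoxycarbonyl)(methyl)amino)ethyl in place of (4-(methoxycarbonyl)piperazin-1-yl)methyl on a saturated chain carbon bound to an amine nitrogen in a ring. Among the compounds with values here, nothing in the measured set bears directly on this change: the only step on record concerns a substituent on the aromatic core, not the basic side chain, and compounds 1 and 3 differ from compound 2 in more than one place. The expectation for this assay therefore rests on little more than the range spanned by the three measured compounds. A modest step upward seems most plausible, giving an expected 3.1-fold higher number from compound 2 to compound 4 (0.50 log units; beyond the scatter). For compound 4 the estimate is 5 nM, with a range from 1.5 nM to 16 nM.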

Compound 4, half-maximal effective concentration: 2 nM
Compound 4: the middle estimate sits 2.5-fold (0.40 log units) above what was measured, and the stated range covers the measured number.
By their numbers in this assay, from the lowest: compounds 2, 4 and 3 (each within the scatter of the next); then compound 1.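

In this assay, the exchange of (4-(methoxycarbonyl)piperazin-1-yl)methyl for 1-hydroxy-2-((methoxycarbonyl)(methyl)amino)ethyl on a saturated chain carbon bound to an amine nitrogen in a ring gives a 1.3-fold higher number from compound 2 to compound 4 (0.10 log units; within the scatter), so the two compounds cannot be ranked against each other. Going by these compounds alone, this is the first step on record at this position, and it shows that, in this one pair, the number stays within the scatter although the six-membered ring with 2 hetero atoms is gone and the entering group has 1 hydrogen-bond donor where the leaving group has none. Within the data shown here, no supporting measurement is available to explain this result, and the single step cannot separate the loss of the ring from the gain of the hydroxyl group.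

The compounds shown leave open whether a carboxylic acid or a primary amine could stand in place of the methoxycarbonyl group, and whether a longer chain would keep the number in this range. They also leave open whether the same exchange would give a similar step on a core bearing tert-butyl or hydrogen.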